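A few compounds are considered here, and "the series" means these few. Any claim that something is new, unique, unknown or untested is made for them only; others in the source may bear on it.

In an ADME assay on MRC5 cells (Homo sapiens) for cytotoxicity, read by MTT assay, with a stated time of 72 h; on this read-out higher numbers stand for weaker inhibition and lower numbers for stronger inhibition:
- compound 1 (`CC1=CCC[C@H]2[C@](C)(CC3=CC(=O)C=CC3=O)[C@@H](C)CC[C@]12C`): > 200000 nM (a limit)
- compound 2 (`CC1=CCC[C@H]2[C@](C)(CC3=CC(=O)C=C(N[C@@H](CC(C)C)C(=O)O)C3=O)[C@@H](C)CC[C@]12C`): 73400 nM
- compound 3 (`CSCC[C@H](NC1=CC(=O)C=C(C[C@]2(C)[C@@H](C)CC[C@]3(C)C(C)=CCC[C@@H]23)C1=O)C(=O)O`): > 200000 nM (a limit)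

Compound 3 stands only at a limit (the limit of > 200000 nM in this assay, at which 2 of the 3 values shown sit). The change to compound 4 (`CC1=CCC[C@H]2[C@](C)(CC3=CC(=O)C=C(NCCC(=O)O)C3=O)[C@@H](C)CC[C@]12C`) puts 2-carboxyethyl in place of 1-carboxy-3-(methylsulfanyl)propyl on an amine nitrogen. Two readable steps bear on it (an at least 2.7-fold lower number from compound 1 to compound 2 (0.43 log units; beyond the scatter); an at least 2.7-fold higher number from compound 2 to compound 3 (0.43 log units; beyond the scatter)), and both show that the group on this nitrogen can shift the number. The third (a step that the two limits leave unreadable from compound 1 to compound 3) gives no size. For compound 4 the expected step is an at least 1.4-fold lower number from compound 3 to compound 4 (0.15 log units; that floor lies within the scatter) in the direction of a lower number, of modest size, and a reading at the limit remains possible. For compound 4 the estimate is 140000 nM (expected range 60000 nM to 300000 nM).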

Compound 4, half-maximal inhibitory concentration: 80800 nM
The estimate for compound 4 lay 1.7-fold (0.24 log units) above the measured number; the range from low to high includes it.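

In this assay, a group with no defined stereocentre on the amine nitrogen still gives a readable number, with an at least 2.4-fold lower number from compound 1 to compound 4 (0.39 log units; beyond the scatter). The 2-carboxyethyl and 1-carboxy-3-methylbutyl groups read alike, with a 1.1-fold higher number from compound 2 to compound 4 (0.04 log units; within the scatter). Of the three groups on this nitrogen, only 1-carboxy-3-(methylsulfanyl)propyl stays at a limit, which leaves an at least 2.4-fold lower number from compound 3 to compound 4 (0.39 log units; beyond the scatter) as a floor only, because of that limit: the limit of > 200000 nM in this assay, at which 2 of the 4 values shown sit.

Still open, going by these compounds, is whether the sulfur itself accounts for that limit. Also open, on these data alone, is how an ester or a longer chain carrying the carboxylic acid would read on this amine nitrogen.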